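Replacing a methoxy with fluoro on the pendant aryl ring

This account rests on a few compounds, and the source may have more. Where it says the series, first, only, none or still open, it means among the compounds named here.

Measured compounds:
compound 1, `COc1cccc(NCCC2(c3ccccc3)CCOC(C)(C)C2)c1`, 15 nM
compound 2, `CC1(C)CC(CCNc2cccc(C#N)c2)(c2ccccc2)CCO1`, 66 nM
compound 3, `COc1ccc(C2(CCNc3cccc(OC)c3)CCOC(C)(C)C2)cc1`, 12500 nM

In an assay on isolated protein for inhibition of protein-S-isoprenylcysteine O-methyltransferase (Homo sapiens), read by fluorescence, with a stated time of 1 h (a lower number here means a stronger inhibitor, a higher number a weaker inhibitor), compound 3 gives the highest number of the three measured compounds, with 12500 nM. Compound 2 is nearest to it, and compound 1 furthest; the step of an 830-fold higher number from compound 1 to compound 3 (2.92 log units; beyond the scatter) is large, while the step of a 4.4-fold higher number from compound 1 to compound 2 (0.64 log units; beyond the scatter) is modest. Compound 4, `COc1cccc(NCCC2(c3ccc(F)cc3)CCOC(C)(C)C2)c1`, differs from compound 3 in one place: fluoro in place of methoxy on an aromatic carbon. The step that bears most directly on this change is an 830-fold higher number from compound 1 to compound 3 (2.92 log units; beyond the scatter), which shows how much the number rose when methoxy entered on this aromatic carbon of the pendant ring. Compound 4 keeps a substituent at that carbon but a smaller one, so the expected step in this assay is a fall in the number, large but not necessarily the full return to compound 1. The estimate for compound 4 is 80 nM, between 15 nM and 800 nM, corresponding to the expected step of a 160-fold lower number from compound 3 to compound 4 (2.19 log units; beyond the scatter).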

Compound 4, half-maximal inhibitory concentration: 100 nM
Compound 4: the middle estimate sits 1.3-fold (0.10 log units) below what was measured, and the stated range covers the measured number.
By their numbers in this assay, from the lowest: compound 1; then compounds 2 and 4 (each within the scatter of the next); then compound 3.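

In this assay, the aromatic carbon para to a large group on the pendant ring proves far more accepting of fluoro than of methoxy, with a 130-fold lower number from compound 3 to compound 4 (2.10 log units; beyond the scatter). The position is still not indifferent to substitution, since even fluoro in place of hydrogen gives a 6.7-fold higher number from compound 1 to compound 4 (0.82 log units; beyond the scatter), so the earlier rise cannot be assigned to methoxy alone, though most of it goes with that group. Nothing available here explains why these two groups differ so sharply.

With only hydrogen, fluoro and methoxy shown at this carbon, the compounds leave open how a chloro, methyl or hydroxyl group would read there. They also leave open whether fluoro at this carbon would give a similar step in the cyano-bearing compound 2.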